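Removing a Trifluoromethyl Group from a Benzamide Already at the Limit

The source may hold more compounds than are shown below. What is called first, only, known or untested is meant among the compounds shown, and "the series" means these compounds.

Compound 1, whose structure is `COc1cc(-c2nn(-c3cccc(NC(=O)c4cccc(C(F)(F)F)c4)c3)cc2-c2ccncc2)ccc1Cl`, is one of three pyrazole amides and ureas tested in a functional assay on HCT-116 cells (Homo sapiens) for inhibition, read by sulforhodamine B assay, with a stated time of 48 h; on this read-out lower numbers stand for higher toxicity in this test and higher numbers for lower toxicity in this test. For compound 1 the test reports only a limit, > 50000 nM, and not a number. Compound 2, with structure `O=C(Nc1cccc(-n2cc(-c3ccncc3)c(-c3ccc(Cl)c(O)c3)n2)c1)Nc1cc(C(F)(F)F)cc(C(F)(F)F)c1`, gives 2650 nM in this assay. Compound 3, with structure `COc1cc(-c2nn(-c3cccc(NC(=O)Nc4ccc(Cl)c(C(F)(F)F)c4)c3)cc2-c2ccncc2)ccc1Cl`, gives 21500 nM in this assay. Going by the values given here, the one measured step between compounds that differ in a single place is an at least 2.3-fold lower number from compound 1 to compound 3 (0.36 log units; beyond the scatter); here the starting point is a limit, as noted in the limit of > 50000 nM in this assay, at which 1 of the 3 values shown sits, so the true size of that step is not known.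

Compound 4, with structure `COc1cc(-c2nn(-c3cccc(NC(=O)c4ccccc4)c3)cc2-c2ccncc2)ccc1Cl`, differs from compound 1 in a different way: hydrogen in place of trifluoromethyl on an aromatic carbon. Among the compounds with values here, no measured pair shows this particular change, so the one step on record does not bear on it directly. What is known is that compound 1 sits at the limit of this assay, and a change that removes a single trifluoromethyl group gives no reason to expect a move beyond the scatter in either direction. Compound 4 is therefore expected to show a number no higher from compound 1 to compound 4 (the limit leaves the size open), and its estimated value in this assay is 50000 nM, with a range from 20000 nM to 150000 nM, most likely reported as a limit again.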

Compound 4, concentration lethal to 50% of the cells: > 100000 nM
Compound 4 ended at the assay's limit (the forecaster's own chance of this, stated with the estimate: 70%); middle value at least 2.0-fold (0.30 log units) from the limit.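

In this assay, compound 4 gives > 100000 nM, which is a limit and not a number. Compound 1 also carries a limit, so the change from trifluoromethyl to hydrogen on this aromatic carbon cannot be read as a step, and all that can be said is that neither benzamide reaches a measured value. The comparison that can be read is with the urea, where phenyl on the carbonyl carbon in place of (4-chloro-3-(trifluoromethyl)phenyl)amino gives an at least 4.6-fold higher number from compound 3 to compound 4 (0.66 log units; beyond the scatter), so the benzamide without trifluoromethyl also stays clearly on the less toxic side of compound 3.

Going by these compounds, how far the true values of compound 1 and compound 4 lie past their limits remains unknown, and with it whether the trifluoromethyl group makes any difference at this place in the benzamide. Also open, on these data alone, is whether a different group on the same aromatic carbon, such as an amine or a carboxylic acid, would bring a benzamide into the measurable range of this assay.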